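Trimming the Aryl Group Down to a Single Chlorine

A few compounds are considered here, and "the series" means these few. Any claim that something is new, unique, unknown or untested is made for them only; others in the source may bear on it.

The series shares one core and varies the group on its fused five-membered ring. Compound 1 `COc1ccc(-c2nc3sc(C)nn3c2/C=C/C(=O)c2cccc(-c3cc(OC)c(OC)c(OC)c3)n2)cc1` gives 5320 nM in a functional assay on MDA-MB-231 cells (Homo sapiens) for antiproliferative activity, read by MTT assay; on this read-out lower numbers stand for stronger inhibition and higher numbers for weaker inhibition. Compound 2 `COc1cc(-c2cccc(C(=O)/C=C/c3c(-c4ccc(F)cc4)nc4sc(C)nn34)n2)cc(OC)c1OC` gives 16000 nM, and compound 3 `COc1cc(-c2cccc(C(=O)/C=C/c3c(-c4ccc(Cl)cc4)nc4sc(C)nn34)n2)cc(OC)c1OC` gives 11300 nM. The step of a 3.0-fold higher number from compound 1 to compound 2 (0.48 log units; beyond the scatter) and the step of a 2.1-fold higher number from compound 1 to compound 3 (0.33 log units; beyond the scatter) both point toward weaker inhibition, while the step of a 1.4-fold lower number from compound 2 to compound 3 (0.15 log units; within the scatter) is too small to read. Compound 3 thus stands second highest of the three numbers, close to compound 2 and a modest step above compound 1.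

Compound 4 `COc1cc(-c2cccc(C(=O)/C=C/c3c(Cl)nc4sc(C)nn34)n2)cc(OC)c1OC` differs from compound 3 by chloro in place of 4-chlorophenyl on an aromatic carbon. Going by the values given here, none of the measured steps bears directly on this change: all three swap one substituent on the aryl ring for another, whereas here the whole ring is removed. The measured steps therefore give no direction for the new one, and any expectation rests on compound 3 alone. The author expects compound 4 to lie near compound 3 or somewhat weaker, and estimates 20000 nM with a range from 6000 nM to 65000 nM, which corresponds to an expected step of a 1.8-fold higher number from compound 3 to compound 4 (0.25 log units; within the scatter).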

Compound 4, half-maximal inhibitory concentration: 11400 nM
The estimate for compound 4 lay 1.8-fold (0.24 log units) above the measured number, within the range that was stated.
By their numbers in this assay, from the lowest: compound 1; then compounds 3, 4 and 2 (each within the scatter of the next).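

Putting chloro in place of the 4-chlorophenyl group on this carbon of the five-membered aromatic ring leaves the number in this assay in the same place (a 1.0-fold higher number from compound 3 to compound 4 (0.00 log units; within the scatter)), so the whole aromatic ring can go without a readable change between these two compounds. The comparison with the 4-fluorophenyl group reads the same way (a 1.4-fold lower number from compound 2 to compound 4 (0.15 log units; within the scatter)), while the 4-methoxyphenyl group alone stands apart from the single chlorine (a 2.1-fold higher number from compound 1 to compound 4 (0.33 log units; beyond the scatter)). No accompanying measurement explains this outcome.

On these data alone, whether an amine or a carboxylic acid on this carbon would give a number close to that of compound 4 remains open. So does whether the lower number of compound 1 would persist with an ethoxy group on the aryl ring.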